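The source may hold more compounds than are shown below. What is called first, only, known or untested is meant among the compounds shown, and "the series" means these compounds.

Among the measured compounds shown here, compound 2 `O=C(NO)c1ccc(NCc2nc(-c3ccccc3)nn2-c2ccc(C(F)(F)F)cc2)cc1` gives 38.9% in an assay on Sf9 cells for inhibition of protein deacetylase HDAC6 (Homo sapiens), read by fluorescence, with a stated time of 40 min, tested at 100 nM (a lower number here means less inhibition, a higher number more inhibition at the concentration tested (going by the name of the read-out)), the lowest of the two numbers so far; compound 1 `O=C(NO)c1ccc(NCc2nc(-c3ccccc3)nn2-c2ccc(F)cc2)cc1` gives 67.6%. Compound 3 `Cc1cc(C)cc(-n2nc(-c3ccccc3)nc2CNc2ccc(C(=O)NO)cc2)c1` differs from compound 2 by 3,5-dimethylphenyl in place of 4-(trifluoromethyl)phenyl on an aromatic nitrogen. For the measured compounds named here, the one measured step, a number 28.7 percentage points lower from compound 1 to compound 2 (beyond the scatter), concerns a different change on the same aromatic ring, so no step bears directly on this one. Compound 3 is therefore expected to lie near the two measured numbers, with a step of a number 11.1 percentage points higher from compound 2 to compound 3 (beyond the scatter) judged upward but uncertain. The estimate for compound 3 is 50%, within 25% to 75%.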

Compound 3, a percentage reported as inhibition, at one concentration (the size of the read-out at that concentration, not a potency): 49.8%
The estimate for compound 3 lay 0.2 percentage points above the measured number, and the stated range covers the measured number.
By their numbers in this assay, from the lowest: compound 2; then compound 3; then compound 1.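

In this assay, 3,5-dimethylphenyl on the aromatic nitrogen recovers part of the number lost with 4-(trifluoromethyl)phenyl, giving a number 10.9 percentage points higher from compound 2 to compound 3 (beyond the scatter), but it does not match 4-fluorophenyl, giving a number 17.8 percentage points lower from compound 1 to compound 3 (beyond the scatter), so the three aryl groups stand at separate levels, with each step beyond the scatter. Nothing available explains this order. Still open, on these data alone, is whether an unsubstituted phenyl, a 4-methoxyphenyl or a 4-aminophenyl on this nitrogen would reach or pass compound 1, and whether a single methyl would give the same number as two.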